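The source may hold more compounds than are shown below. What is called first, only, known or untested is meant among the compounds shown, and "the series" means these compounds.

Of the compounds shown here, three have been tested in an ADME assay on HEK-293T cells (Homo sapiens) for inhibition, read by CCK-8 assay, with a stated time of 48 h, tested at 20 uM (on this read-out higher numbers stand for more inhibition of growth at the one concentration tested and lower numbers for less inhibition of growth), and a fourth awaits its number. Compound 1 `COc1ccc(Cc2nnc(NC(=O)/C(C#N)=C/c3ccccc3OS(=O)(=O)c3ccc([N+](=O)[O-])cc3)s2)cc1` gives 17% in this assay. Compound 2 `COc1ccc(Cc2nnc(NC(=O)/C(C#N)=C/c3ccccc3OS(=O)(=O)c3ccccc3[N+](=O)[O-])s2)cc1` differs from compound 1 only by 2-nitrophenyl in place of 4-nitrophenyl on a sulfonyl sulfur, and in this assay compound 2 gives 18%, so the step is a number 1 percentage points higher from compound 1 to compound 2 (within the scatter). Compound 3 `Cc1ccc(Cc2nnc(NC(=O)/C(C#N)=C/c3ccccc3OS(=O)(=O)c3ccc([N+](=O)[O-])cc3)s2)cc1` carries a different core, differing from compound 1 by methyl in place of methoxy on an aromatic carbon; in this assay compound 3 gives 9%, a step of a number 8 percentage points lower from compound 1 to compound 3 (within the scatter). All three values lie within the usual scatter of one another, so none can be called stronger or weaker.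

Compound 4 `Cc1ccc(Cc2nnc(NC(=O)/C(C#N)=C/c3ccccc3OS(=O)(=O)c3ccccc3[N+](=O)[O-])s2)cc1` is not yet measured. It differs from compound 3 by 2-nitrophenyl in place of 4-nitrophenyl on a sulfonyl sulfur, the same change that turns compound 1 into compound 2, at the same place. Since that change gave only a number 1 percentage points higher from compound 1 to compound 2 (within the scatter), compound 4 is expected to show a step of about a number 1 percentage points higher from compound 3 to compound 4 (within the scatter) from compound 3. Compound 4 is therefore estimated at 10%, most likely between 0% and 22%.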

Compound 4, percent growth inhibition at one concentration: 6%
Compound 4: middle estimate off by 4 percentage points, on the high side, and the stated range covers the measured number.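

In this assay, putting 2-nitrophenyl in place of 4-nitrophenyl on the sulfonyl sulfur of the methyl-bearing compounds gives a step of a number 3 percentage points lower from compound 3 to compound 4 (within the scatter), and this reads no differently from the same change on the methoxy-bearing compounds: the same change on two cores in this assay, a number 1 percentage points higher (within the scatter) from compound 1 to compound 2 and a number 3 percentage points lower (within the scatter) from compound 3 to compound 4, 4 percentage points apart, within the scatter of two such steps. Putting methyl in place of methoxy gives a step of a number 12 percentage points lower from compound 2 to compound 4 (beyond the scatter), and this change also reads alike in its two settings: the same change on two cores in this assay, a number 8 percentage points lower (within the scatter) from compound 1 to compound 3 and a number 12 percentage points lower (beyond the scatter) from compound 2 to compound 4, 4 percentage points apart, within the scatter of two such steps. Within these four compounds, then, each change carries over from one core to the other with no detectable difference, but two pairs per change cannot show that this would hold for other compounds, nor do they explain why any step has the size it has.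

The compounds shown leave open how an amine or a carboxylic acid would read on the aromatic carbon that holds the methoxy or methyl. They also leave open how a plain phenyl, without the nitro group, would read on the sulfonyl sulfur.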